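The compounds below may be only part of what the source reports. "The series", "measured", "known", "first", "only" and "open" are said of these compounds alone.

Series notes. Three analogues on a shared core have been read in a functional assay on HEK293 cells for agonist activity at lutropin-choriogonadotropic hormone receptor (Homo sapiens), read by cAMP accumulation; on this read-out lower numbers stand for an effect already at smaller amounts and higher numbers for an effect only at larger amounts of compound. Compound 1 `CSc1nc(-c2cccc(O)c2)c2c(N)c(C(=O)NC(C)(C)C)sc2n1` gives 1900 nM. Compound 2 `CSc1nc(-c2cccc(F)c2)c2c(N)c(C(=O)NC(C)(C)C)sc2n1` gives 1200 nM in this assay. Compound 3 `COc1cccc(-c2nc(SC)nc3sc(C(=O)NC(C)(C)C)c(N)c23)c1F` gives 1500 nM in this assay and sits between the other two numbers, within the scatter of each: a 1.3-fold higher number from compound 2 to compound 3 (0.10 log units; within the scatter) and a 1.3-fold lower number from compound 1 to compound 3 (0.10 log units; within the scatter). Compound 4 `COc1cccc(-c2nc(SC)nc3sc(C(=O)NC(C)(C)C)c(N)c23)c1OC` is not yet measured; it differs from compound 3 by methoxy in place of fluoro on an aromatic carbon. Going by the values given here, no measured step exchanges fluoro for methoxy. Among the compounds with values here, the steps that bear on it are changes on the same aromatic ring, and each lies within the scatter: a 1.6-fold lower number from compound 1 to compound 2 (0.20 log units; within the scatter), a 1.3-fold lower number from compound 1 to compound 3 (0.10 log units; within the scatter), a 1.3-fold higher number from compound 2 to compound 3 (0.10 log units; within the scatter). No step beyond the scatter is therefore expected in this assay, in either direction. Compound 4 is estimated at 1500 nM, range 600 nM to 4000 nM. The expected step is no change at the digits printed from compound 3 to compound 4 (within the scatter).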

Compound 4, half-maximal effective concentration: 800 nM
Compound 4: the middle estimate sits 1.9-fold (0.27 log units) above what was measured; measured number inside the range.
By their numbers in this assay, from the lowest: compounds 4, 2, 3 and 1 (each within the scatter of the next, the first and the last beyond it).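

On the aromatic carbon ortho to a large group and ortho to a methoxy group, methoxy in place of fluoro gives a 1.9-fold lower number from compound 3 to compound 4 (0.27 log units; within the scatter) in this assay. Going by these compounds alone, this is the first reading of this exchange at this position, and methoxy is accommodated there with no step beyond the scatter. Nothing available speaks to the reason for this result.

From the compounds shown here alone, whether an amine, a carboxylic acid or a longer chain such as butoxy on this carbon would also stay within the scatter remains open. Also open, going by these compounds, is whether the same exchange would read alike without the other methoxy group on the ring.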